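Series notes: arylthio-tetrazole acetanilides, liver microsome half-life

This account rests on a few compounds, and the source may have more. Where it says the series, first, only, none or still open, it means among the compounds named here.

Measured so far:
compound 1 `O=C(CSc1nnnn1-c1cccc2ccccc12)Nc1ccccc1Cl` — 0.1 h
compound 2 `Cc1ccc(-n2nnnc2SCC(=O)Nc2ccccc2Cl)c(Cl)c1` — 0.0333 h
compound 3 `CC(C)(C)c1ccc(-n2nnnc2SCC(=O)Nc2ccccc2Cl)c(Cl)c1` — 0.133 h

Compound 3 stands highest of the three numbers in an in vitro ADME assay on microsomes from liver (Homo sapiens) for metabolic stability; a lower number here means that the compound disappears faster, a higher number that the compound lasts longer. Going by the values given here, its gap to compound 1 is within the scatter; its gap to compound 2 is beyond it, the one measured step in this assay being a 4.0-fold higher number from compound 2 to compound 3 (0.60 log units; beyond the scatter), a modest change.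

Compound 4 `CC(C)(C)c1ccc(-n2nnnc2SCC(=O)Nc2ccc(-c3ccc(OCC(=O)O)cc3)cc2Cl)c(Cl)c1` is the next compound. The change from compound 3 is 4-(carboxymethoxy)phenyl in place of hydrogen on an aromatic carbon. Among the compounds with values here, no measured step bears on this change: the single step above swaps one alkyl group for another on the ring attached to the tetrazole, whereas here a large substituent enters on the anilide ring, a part of the molecule left untouched in all three measured compounds. There is therefore no basis in these data for expecting a step in either direction beyond the scatter.

For compound 4 the half-life in this assay is expected to stay near that of compound 3, estimated at 0.15 h (range 0.05 h to 0.5 h), which means an expected step of a 1.1-fold higher number from compound 3 to compound 4 (0.05 log units; within the scatter).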

Compound 4, half-life: 0.117 h
Estimate against measurement, compound 4: 1.3-fold (0.11 log units) above; low and high end bracket the measured number.
By their numbers in this assay, from the lowest: compound 2; then compounds 1, 4 and 3 (each within the scatter of the next).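

Going by these compounds alone, compound 4 gives the first reading on a change at this position, an aromatic carbon meta to a chloro group and para to a large group, where compounds 1, 2 and 3 all carry hydrogen. In this assay the entry of 4-(carboxymethoxy)phenyl gives a 1.1-fold lower number from compound 3 to compound 4 (0.06 log units; within the scatter), so a group of 11 heavy atoms, with its own six-membered aromatic ring, can stand at this position without a step beyond the scatter. Nothing measured on this series bears on the reason for this result.

Open, as far as these compounds go, is how a plain phenyl, a methyl ester of the same chain, or an amine in place of the carboxylic acid would read at this position. Also open, from the compounds shown here alone, is whether the same group would give a comparable reading with methyl in place of tert-butyl, as in compound 2.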